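A few compounds are considered here, and "the series" means these few. Any claim that something is new, unique, unknown or untested is made for them only; others in the source may bear on it.

Measured so far:
compound 1 `COc1ccc(S(=O)(=O)NC(=O)Nc2ccc(Cl)cc2)s1`: 100%
compound 2 `O=C(Nc1ccc(Cl)cc1)NS(=O)(=O)c1cc(Br)c(Br)s1`: 52%

In a functional assay on the whole organism (6C3HED cells, Mus musculus) for inhibition, at a dose of 300 mg/kg by the oral route (on this read-out higher numbers stand for more inhibition at the one dose given (going by the name of the read-out) and lower numbers for less inhibition), compound 2 stands lowest of the two numbers; the step of a number 48 percentage points lower from compound 1 to compound 2 (beyond the scatter) was large. Compound 3 `Cc1cc(S(=O)(=O)NC(=O)Nc2ccc(Cl)cc2)sc1C` differs from compound 2 by 4,5-dimethylthiophen-2-yl in place of 4,5-dibromothiophen-2-yl on a sulfonyl sulfur. Among the measured compounds shown here, the step from compound 1 to compound 2 bears on this change only loosely: it shows that swapping the group on the sulfonyl sulfur can shift this assay a great deal, but no measured step sets the dimethyl group against the dibromo group. A rise of uncertain size is expected, so compound 3 is estimated at 70%, within 35% to 100%. The expected step is a number 18 percentage points higher from compound 2 to compound 3 (beyond the scatter).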

Compound 3, a percentage reported as inhibition, in the whole organism at one dose (the size of the read-out at that dose, not a potency): 73%
For compound 3 the middle estimate is 3 percentage points below the measured one; low and high end bracket the measured number.
By their numbers in this assay, from the lowest: compound 2; then compound 3; then compound 1.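

In this assay, 4,5-dimethylthiophen-2-yl in place of 4,5-dibromothiophen-2-yl on the sulfonyl sulfur gives a number 21 percentage points higher from compound 2 to compound 3 (beyond the scatter), so two groups with equal heavy-atom counts still read differently here. Set against 5-methoxythiophen-2-yl, the dimethyl group gives a number 27 percentage points lower from compound 1 to compound 3 (beyond the scatter), which spreads all three groups apart by more than the scatter. Nothing measured here accounts for this order.

Going by these compounds, what remains open is whether a thiophene carrying a single methyl or a single bromine would fall within this range. On these data alone, it is also open how a thiophene carrying an amine or a carboxylic acid would compare.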